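A few compounds are considered here, and "the series" means these few. Any claim that something is new, unique, unknown or untested is made for them only; others in the source may bear on it.

Working notes on the oxindole thiosemicarbazone series, all tested in a functional assay on HCT-116 cells (Homo sapiens) for inhibition, read by MTT assay, with a stated time of 72 h; a higher number here means a weaker inhibitor, a lower number a stronger inhibitor.

Measured so far:
- compound 1, `O=C1Nc2ccccc2/C1=N/NC(=S)N1CCN(c2ccccc2)CC1`: 11100 nM
- compound 2, `O=C1Nc2ccc(F)cc2/C1=N/NC(=S)N1CCN(c2ccccc2)CC1`: 12400 nM
- compound 3, `O=C1Nc2ccc(Cl)cc2/C1=N/NC(=S)N1CCN(c2ccccc2F)CC1`: 8290 nM

Compound 1 and compound 2 differ in one place: fluoro in place of hydrogen on an aromatic carbon. The step is a 1.1-fold higher number from compound 1 to compound 2 (0.05 log units; within the scatter), so this substitution leaves the readout where it was. Compound 3 carries a different core from compound 1, and that difference between the two cores is not broken down here; the value of compound 3 in this assay sits within the usual scatter of both compound 1 and compound 2, so no ordering among the three can be read from these numbers.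

Compound 4, `O=C1Nc2ccc(Cl)cc2/C1=N/NC(=S)N1CCN(c2ccc(F)cc2F)CC1`, remains to be measured. It differs from compound 3 in one place: fluoro in place of hydrogen on an aromatic carbon. This is the same kind of change as that from compound 1 to compound 2, but not the same: there the entering fluoro sat on a ring that is part of a fused or bridged system of two rings, meta to a fused ring and para to a fused ring, whereas here it sits on a six-membered aromatic ring of carbon only, meta to a fluoro group and para to a large group. Within the data shown here, the only guide is compound 1 to compound 2, where the step was a 1.1-fold higher number from compound 1 to compound 2 (0.05 log units; within the scatter). On that basis the step from compound 3 to compound 4 in this assay is expected to be small, about a 1.1-fold higher number from compound 3 to compound 4 (0.04 log units; within the scatter). Compound 4 is therefore estimated at 9000 nM, with the likely range 4500 nM to 18000 nM.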

Compound 4, half-maximal inhibitory concentration: 5890 nM
For compound 4 the middle estimate is 1.5-fold (0.18 log units) above the measured one; the range from low to high includes it.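

In this assay, taking 2-fluorophenyl to 2,4-difluorophenyl gives a 1.4-fold lower number from compound 3 to compound 4 (0.15 log units; within the scatter), so this fluoro in place of hydrogen leaves the readout within the usual scatter. Set beside the earlier fluoro step, the change shows no detectable dependence on the core across these two pairs: the same change on two cores in this assay, a 1.1-fold higher number (0.05 log units; within the scatter) from compound 1 to compound 2 and a 1.4-fold lower number (0.15 log units; within the scatter) from compound 3 to compound 4, 1.6-fold (0.20 log units) apart, within the scatter of two such steps This does not show that the change is neutral throughout the series or that its effect carries over to other cores, since there are only two pairs, and the entering fluoro sits on a ring of a fused or bridged system in one and on a six-membered aromatic ring of carbon only in the other.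

The compounds shown vary these rings only through hydrogen, fluoro and chloro, so it remains open whether a methoxy group, a trifluoromethyl group, an amine or a carboxylic acid in place of the entering fluoro would give a step beyond the scatter. Also open, going by these compounds, is whether 2-fluorophenyl and 2,4-difluorophenyl would read the same on the core of compound 1, which would separate the effect of these groups from that of the chloro carried by compound 3 and compound 4.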